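Extending an ether on the aromatic ring of compound 2

This account rests on a few compounds, and the source may have more. Where it says the series, first, only, none or still open, it means among the compounds named here.

Four closely related compounds are considered here, all sharing one core and differing in two places: the length of the chain between the two ends of the molecule, and the group attached to an oxygen on an aromatic ring. In an assay on CHO cells for displacement of a labelled ligand from 5-hydroxytryptamine receptor 7 (Homo sapiens), read by scintillation counting, with a stated time of 60 min (on this read-out higher numbers stand for weaker inhibition and lower numbers for stronger inhibition), compound 1 `COc1ccc(/C=C2\NC(=O)N(CCCN3CCN(c4ccccc4OC)CC3)C2=O)cc1OC` gives 42 nM. Compound 2 `COc1ccc(/C=C2\NC(=O)N(CCCCN3CCN(c4ccccc4OC)CC3)C2=O)cc1OC` gives 16 nM in this assay. Compound 3 `COc1ccc(/C=C2\NC(=O)N(CCCN3CCN(c4ccccc4OC)CC3)C2=O)cc1OC1CCCC1` gives 6 nM in this assay.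

Compound 3 differs from compound 1 by one change, (cyclopentyl in place of methyl on an oxygen on an aromatic ring), and that change produced a 7.0-fold lower number from compound 1 to compound 3 (0.85 log units; beyond the scatter). How compound 2 differs from compound 1, the difference between the two cores, is not broken down here; the two values simply show that compound 2 gives the lower number of the two.

Compound 4 `COc1ccc(/C=C2\NC(=O)N(CCCCN3CCN(c4ccccc4OC)CC3)C2=O)cc1OC1CCCC1` has not yet been measured in this assay. It differs from compound 2 by cyclopentyl in place of methyl on an oxygen on an aromatic ring, the same change that turned compound 1 into compound 3, made at a place described in the same words. Because compound 1 to compound 3 gave a 7.0-fold lower number from compound 1 to compound 3 (0.85 log units; beyond the scatter), a step of similar size is expected from compound 2, namely a 6.4-fold lower number from compound 2 to compound 4 (0.81 log units; beyond the scatter). This expectation rests on a single earlier example, so it carries real uncertainty. On that basis, compound 4 is estimated to give 2.5 nM in this assay, with a likely range from 1 nM to 7 nM.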

Compound 4, inhibition constant: 1 nM
For compound 4 the middle estimate is 2.5-fold (0.40 log units) above the measured one, within the range that was stated.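

In this assay, putting cyclopentyl in place of methyl on an oxygen on an aromatic ring gives a 16-fold lower number from compound 2 to compound 4 (1.20 log units; beyond the scatter) on the core of compound 2, so the change again lowers the number and the binding measured here becomes stronger. Set beside the earlier example, the step points the same way and its size cannot be told apart from the first: the same change on two cores in this assay, a 7.0-fold lower number (0.85 log units; beyond the scatter) from compound 1 to compound 3 and a 16-fold lower number (1.20 log units; beyond the scatter) from compound 2 to compound 4, 2.3-fold (0.36 log units) apart, within the scatter of two such steps. Among the compounds shown here, this shows that the change carried over between these two cores, which differ in the length of the chain, but with only two pairs it does not show that the step is larger on the core of compound 2, that it would hold on any other core, or why the cyclopentyl group gives a lower number than the methyl group.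

Still open, as far as these compounds go, is how the number responds to other groups on that same oxygen, such as ethyl, isopropyl or cyclohexyl, which would show whether a ring is needed or whether a different carbon group serves as well. For the compounds shown here, also open is how this change behaves with a longer chain than the one in compound 4, and whether the lower numbers hold for any receptor other than the one tested here.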